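The source may report more compounds than this note shows. Statements on the series, on what has been measured and on what is new or still open speak of the compounds shown alone.

Measured so far in an assay for displacement of a labelled ligand from Adrenergic receptor alpha-1 (Homo sapiens); a higher number here means a weaker inhibitor, a lower number a stronger inhibitor:
- compound 1, `CNc1ccccc1N1CCN(CCCCn2ncc(=O)n(C)c2=O)CC1`: compound 1 gives 450 nM
- compound 2, `CSc1ccccc1N1CCN(CCCCn2ncc(=O)n(C)c2=O)CC1`: compound 2 gives 1.8 nM
- compound 3, `Cn1c(=O)cnn(CCCCN2CCN(c3ccccc3)CC2)c1=O`: compound 3 gives 64 nM

Compound 3 holds the second highest of the three numbers in this assay. Its nearest neighbour is compound 1, and the gap is a 7.0-fold lower number from compound 1 to compound 3 (0.85 log units; beyond the scatter); its furthest is compound 2, and that gap is a 36-fold higher number from compound 2 to compound 3 (1.55 log units; beyond the scatter).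

Compound 4, `Cn1c(=O)cnn(CCCCN2CCN(c3ccccc3F)CC2)c1=O`, is compound 3 with one change: fluoro in place of hydrogen on an aromatic carbon. Going by the values given here, two measured steps bear on this. Both alter the same aromatic carbon. Going a 36-fold higher number from compound 2 to compound 3 (1.55 log units; beyond the scatter) removes methylsulfanyl, and going a 7.0-fold lower number from compound 1 to compound 3 (0.85 log units; beyond the scatter) removes methylamino; the number in this assay moves in opposite directions, so the outcome plainly depends on which group occupies that carbon. Fluoro is neither of these, and no measured compound carries it, so the direction of the step is not fixed by the data. The expectation is a small to modest lowering of the number, with real uncertainty on either side: the step from compound 3 to compound 4 is estimated as a 1.8-fold lower number from compound 3 to compound 4 (0.26 log units; within the scatter). Compound 4 is therefore expected to give about 35 nM in this assay, within a range of 8 nM to 150 nM.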

Compound 4, inhibition constant: 9.73 nM
Compound 4: middle estimate off by 3.6-fold (0.56 log units), on the high side; low and high end bracket the measured number.
By their numbers in this assay, from the lowest: compound 2; then compound 4; then compound 3; then compound 1.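

In this assay, a single fluoro on this aromatic carbon, ortho to a large group, gives a 6.6-fold lower number from compound 3 to compound 4 (0.82 log units; beyond the scatter) and so lowers the number relative to hydrogen. Fluoro thus acts in the same direction as methylsulfanyl and against methylamino, yet it does not match methylsulfanyl, with a 5.4-fold higher number from compound 2 to compound 4 (0.73 log units; beyond the scatter) and a clear separation from methylamino, with a 46-fold lower number from compound 1 to compound 4 (1.67 log units; beyond the scatter) completing an order of methylsulfanyl, fluoro, hydrogen and methylamino from the lowest number to the highest. Nothing measured here accounts for that order.

As far as these compounds go, whether other groups on this carbon, such as chloro, methoxy or hydroxyl, would fall within this order or outside it remains open, and four compounds cannot show which feature of a group decides its place. Also open, from the compounds shown here alone, is whether the lowering seen on going from hydrogen to fluoro would persist with a shorter or longer chain in place of the present one, or with a different group on the shared core.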